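The source may hold more compounds than are shown below. What is called first, only, known or untested is meant among the compounds shown, and "the series" means these compounds.

Measured in a functional assay on CCRF-CEM cells (Homo sapiens) for inhibition; a lower number here means a stronger inhibitor, a higher number a weaker inhibitor:
- Compound 1 `O=C1CCCCC/C1=C\c1cccc(F)c1`: 224000 nM
- Compound 2 `O=C1CCCCC/C1=C\c1cccc(Br)c1`: 137000 nM
- Compound 3 `Cc1ccc(/C=C2\CCCCCC2=O)cc1`: > 500000 nM (a limit, not a number)

Only two of these compounds have an actual number, and those numbers cannot be told apart. The comparison gives a 1.6-fold lower number from compound 1 to compound 2 (0.21 log units; within the scatter), so compound 2 stands level with compound 1 in this assay. For compound 3 the assay reports only a limit, > 500000 nM.

The next compound to be tested is compound 4 `O=C1CCCCC/C1=C\c1cccc([N+](=O)[O-])c1`, which keeps the core of compound 2 and changes one group: nitro in place of bromo on an aromatic carbon. In words, this is nitro in place of bromo on an aromatic carbon. Among the compounds with values here, only one measured step bears on this change, the exchange of bromo for fluoro, and it stayed within the scatter. Within the data shown here, no measured step involves nitro, so this evidence is thin. With so little to go on, no shift beyond the scatter is expected in this assay, and no direction can be favoured with confidence. The expected change is a 1.1-fold higher number from compound 2 to compound 4 (0.04 log units; within the scatter). A reading that gives only a limit also remains possible. For compound 4 the estimated value is 150000 nM, with an expected range from 50000 nM to 400000 nM.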

Compound 4, half-maximal inhibitory concentration: 30100 nM
Estimate against measurement, compound 4: 5.0-fold (0.70 log units) above; the whole stated range lies above it.
By their numbers in this assay, from the lowest: compound 4; then compounds 2 and 1 (each within the scatter of the next). At a limit, above all of these: compound 3.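

In this assay the exchange of bromo for fluoro stayed within the scatter, so this aromatic carbon could have seemed indifferent to the group it carries. Nitro changes that picture: the step to it is a 4.6-fold lower number from compound 2 to compound 4 (0.66 log units; beyond the scatter) and, counted from the fluoro compound, a 7.4-fold lower number from compound 1 to compound 4 (0.87 log units; beyond the scatter), both beyond the scatter, so the choice of group at this place does move the reading. Nothing measured in this set says why nitro parts from the two halogens, and the reason for the lower number stays unexplained.

The compounds shown leave open whether this step belongs to nitro alone or would also appear with another group on the same carbon, such as a nitrile, an amine or a carboxylic acid. They also leave open whether nitro would give a step of this size on a different carbon of the same aromatic ring, with the rest of the molecule unchanged.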